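The compounds below may be only part of what the source reports. "The series", "measured", "known", "first", "only" and "open" are said of these compounds alone.

Compound 2, with the structure `Cc1c(CCOCCO[N+](=O)[O-])cc(-c2ccc(S(C)(=O)=O)cc2)n1-c1cccc(F)c1`, is the starting point of this step. In an assay on J774 cells for inhibition of prostaglandin G/H synthase 1 (Mus musculus), read by immunoassay, with stated times of 15 min and 30 min (on this read-out higher numbers stand for weaker inhibition and lower numbers for stronger inhibition), compound 2 gives > 10000 nM, which is a limit of the assay rather than a measured number. For the measured compounds named here, its single measured neighbour is compound 1, with the structure `Cc1c(CCOCCO[N+](=O)[O-])cc(-c2ccc(S(C)(=O)=O)cc2)n1-c1ccccc1`. In this assay compound 1 gives > 10000 nM, again a limit of the assay and not a number. Going by the values given here, the one measured step, a step that the two limits leave unreadable from compound 1 to compound 2, therefore has no readable size, since both ends sit at the limit of > 10000 nM in this assay, at which 2 of the 2 values shown sit.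

Compound 3, with the structure `Cc1c(CCOCCO[N+](=O)[O-])cc(-c2ccc(S(C)(=O)=O)cc2)n1-c1ccc(F)c(F)c1`, is not yet measured. It differs from compound 2 by fluoro in place of hydrogen on an aromatic carbon. Among the compounds with values here, the only measured step, a step that the two limits leave unreadable from compound 1 to compound 2, concerns a change of the same kind but is unreadable, so no direction and no size can be taken from it for this assay; the expectation for compound 3 is that its value will again be reported as a limit. The step that the limit leaves unreadable from compound 2 to compound 3 is thus expected to be none beyond the scatter. The estimate for compound 3 in this assay is 20000 nM, with a range from 5000 nM to 80000 nM.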

Compound 3, half-maximal inhibitory concentration: > 10000 nM
Compound 3 was reported as a limit; the forecaster's own chance of this, stated with the estimate: 85%; the middle value lies beyond the limit too.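

In this assay, for the compounds shown here, no step among compound 1, compound 2 and compound 3 can be read, because each of the three values is a limit of the assay and not a number: the limit of > 10000 nM in this assay, at which 3 of the 3 values shown sit. The compounds shown leave open how strongly any of the three inhibits, and whether fluoro in place of hydrogen on an aromatic carbon changes that inhibition at all.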